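The source may report more compounds than this note shows. Statements on the series, on what has been measured and on what is new or still open speak of the compounds shown alone.

The measured compounds:

Compound 1, `COC(=O)c1cccn1-c1ccc(Nc2ncc(Cl)c(Nc3ccccc3NS(C)(=O)=O)n2)c(OC)c1`: in a functional assay on NCI-H2228 cells (Homo sapiens) for antiproliferative activity, read by MTT assay, with a stated time of 72 h (a lower number here means a stronger inhibitor, a higher number a weaker inhibitor), compound 1 gives 950 nM.
Compound 2, `COc1cc(-n2cccc2C(=O)N2CCCCC2)ccc1Nc1ncc(Cl)c(Nc2ccccc2NS(C)(=O)=O)n1`: in this assay compound 2 gives 630 nM.
Compound 3, `COc1cc(-n2cccc2C(=O)NCCO)ccc1Nc1ncc(Cl)c(Nc2ccccc2NS(C)(=O)=O)n1`: in this assay compound 3 gives 34 nM.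

Compound 2 stands second highest of the three numbers: its nearest neighbour is compound 1, with a 1.5-fold lower number from compound 1 to compound 2 (0.18 log units; within the scatter), and its furthest is compound 3, with a 19-fold lower number from compound 2 to compound 3 (1.27 log units; beyond the scatter). The step to compound 3, like a 28-fold lower number from compound 1 to compound 3 (1.45 log units; beyond the scatter), is large.

Compound 4, `CCN(CC)C(=O)c1cccn1-c1ccc(Nc2ncc(Cl)c(Nc3ccccc3NS(C)(=O)=O)n2)c(OC)c1`, has not yet been measured. It differs from compound 2 in one place: diethylamino in place of piperidin-1-yl on a carbonyl carbon. Both groups are tertiary amines on the carbonyl, with no hydrogen-bond donor or acceptor counted in either.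

The step that bears most on this change is a 1.5-fold lower number from compound 1 to compound 2 (0.18 log units; within the scatter), where one tertiary-type substituent replaced methoxy and the number stayed within the scatter. The large steps to compound 3 involve the (2-hydroxyethyl)amino group, which compound 4 does not carry, so they give no direct guide. Compound 4 is therefore expected to show a step of a 1.1-fold lower number from compound 2 to compound 4 (0.02 log units; within the scatter), that is, none beyond the scatter. The estimate for compound 4 in this assay is 600 nM, within a range from 300 nM to 1400 nM.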

Compound 4, half-maximal inhibitory concentration: 870 nM
Compound 4: the middle estimate sits 1.5-fold (0.16 log units) below what was measured; the range from low to high includes it.
By their numbers in this assay, from the lowest: compound 3; then compounds 2, 4 and 1 (each within the scatter of the next).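

In this assay, diethylamino in place of piperidin-1-yl on this carbonyl carbon gives a 1.4-fold higher number from compound 2 to compound 4 (0.14 log units; within the scatter) and so shows that, in this pair, the amide need not carry the six-membered ring for its number to stay within the scatter. Compound 4 also shows a 1.1-fold lower number from compound 1 to compound 4 (0.04 log units; within the scatter) when set against the methoxy compound, while a 26-fold higher number from compound 3 to compound 4 (1.41 log units; beyond the scatter) leaves compound 3 apart from all three compounds without the (2-hydroxyethyl)amino group. Nothing measured here accounts for that separation.

As far as these compounds go, it remains open whether the large step depends on the hydroxyl of the (2-hydroxyethyl)amino group or on the amide hydrogen, which an ethylamino or a 2-methoxyethylamino group on the same carbonyl carbon could separate. From the compounds shown here alone, whether a longer chain such as 3-hydroxypropylamino, or a carboxylic acid here, would stand with compound 3 also remains unknown.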